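A few compounds are considered here, and "the series" means these few. Any claim that something is new, unique, unknown or untested is made for them only; others in the source may bear on it.

Compound 3 `O=C1N(Cc2ccccc2)c2cccn2S(=O)(=O)N1Cc1ccccc1` is a small molecule tested for its toxicity toward cultured human cells. In an ADME assay on MT4 cells (Homo sapiens) for cytotoxicity, read by MTT assay, with a stated time of 5 days (on this read-out higher numbers stand for lower toxicity in this test and lower numbers for higher toxicity in this test), compound 3 gives 196000 nM. Compound 2 `O=C1N(Cc2cccc(Cl)c2)c2cccn2S(=O)(=O)N1Cc1ccccc1` carries a chloro group on one of its benzyl rings, and in this assay compound 2 gives 196000 nM, so that compound 3 stands level with compound 2. Compound 1 `O=C1N(Cc2ccccc2)c2cccn2S(=O)(=O)N1Cc1cccc(F)c1` carries a fluoro group on the other benzyl ring. For compound 1 this assay reports only a limit, > 288000 nM, not a number. Compound 4 `O=C1N(Cc2ccccc2Br)c2cccn2S(=O)(=O)N1Cc1ccccc1` has not yet been measured; it differs from compound 3 in one place: bromo in place of hydrogen on an aromatic carbon. Among the measured compounds shown here, two measured steps bear on this change: no change at the digits printed from compound 2 to compound 3 (within the scatter) and an at least 1.4-fold lower number from compound 1 to compound 3 (0.16 log units; that floor lies within the scatter). Both remove a halogen from a benzyl ring and both stay within the scatter, so putting a halogen back onto compound 4 is expected to give a step of no change at the digits printed from compound 3 to compound 4 (within the scatter) in this assay, that is, no change beyond the scatter. Compound 4 is therefore estimated at 196000 nM, with a range from 100000 nM to 350000 nM.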

Compound 4, half-maximal cytotoxic concentration: 226000 nM
Beside the measured number, compound 4's estimate is 1.2-fold (0.06 log units) below it, within the range that was stated.
By their numbers in this assay, from the lowest: compounds 2, 3 and 4 (each within the scatter of the next). At a limit, above all of these: compound 1.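

In this assay, among the compounds shown here, the 2-bromobenzyl group of compound 4 adds a third halogen, and it sits ortho to a large group, a place on the ring that the earlier compounds did not cover. Adding bromo at this place gives a 1.2-fold higher number from compound 3 to compound 4 (0.06 log units; within the scatter). Exchanging the 3-chlorophenyl for a 2-bromophenyl gives a 1.2-fold higher number from compound 2 to compound 4 (0.06 log units; within the scatter), so among compounds 2, 3 and 4, neither the choice between chloro and bromo nor the move to this place shifts the number beyond the scatter.

Going by these compounds, compound 1 has only a limit, not a number, so the size of its fluoro step stays open: the limit of > 288000 nM in this assay, at which 1 of the 4 values shown sits. On these data alone, whether an amine or a carboxylic acid at this same place would move the number beyond the scatter also stays open.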